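A few compounds are considered here, and "the series" means these few. Any claim that something is new, unique, unknown or untested is made for them only; others in the source may bear on it.

The work rests on two cores. Compound 1 `CC(C)(C)c1ccc(Cn2cc(C#N)c3c(N)ncnc32)cc1` and compound 3 `CC(C)(C)c1ccc(Cn2cc(C(=N)S)c3c(N)ncnc32)cc1` share one of them; compound 2 `Cn1cc(C#N)c2c(N)ncnc21` and the still unmeasured compound 4 `Cn1cc(C(=N)S)c2c(N)ncnc21` share the other. The difference between the two cores is not broken down here.

In a functional assay on KB cells (Homo sapiens) for cytotoxicity (on this read-out higher numbers stand for weaker inhibition and lower numbers for stronger inhibition), compound 1 gives 3000 nM and compound 3 gives 7000 nM. The change between them is a group of 3 heavy atoms (1 carbon, 1 nitrogen, 1 sulfur; no ring) in place of a group of 2 heavy atoms (1 carbon, 1 nitrogen; no ring), on an aromatic carbon, and it made a 2.3-fold higher number from compound 1 to compound 3 (0.37 log units; beyond the scatter). Compound 2 reaches only a limit of this assay and not a number, > 100000 nM. That is the meaning of the limit of > 100000 nM in this assay, at which 1 of the 3 values shown sits.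

The change from compound 2 to compound 4 is a group of 3 heavy atoms (1 carbon, 1 nitrogen, 1 sulfur; no ring) in place of a group of 2 heavy atoms (1 carbon, 1 nitrogen; no ring), on an aromatic carbon. It is the same kind of change as that from compound 1 to compound 3, not the same change: in one pair the ring atom that stands two ring bonds from the place bears a methyl group, in the other it bears a large group.

For compound 4 the step expected from compound 2 in this assay is a step that the limit leaves unreadable from compound 2 to compound 4. That expectation rests on the modest size of a 2.3-fold higher number from compound 1 to compound 3 (0.37 log units; beyond the scatter) and on compound 2 already standing at a limit of this assay, so that a further weakening cannot be seen as a number. Compound 4 is therefore estimated to sit at about 230000 nM, between 100000 nM and 1000000 nM, most probably again as a limit rather than a number.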

Compound 4, half-maximal inhibitory concentration: 15000 nM
Compound 4: middle estimate off by 15-fold (1.19 log units), on the high side, and the stated range ends above it.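

In this assay, replacing cyano with the new group on the core of compound 2 made an at least 6.6-fold lower number from compound 2 to compound 4 (0.82 log units; beyond the scatter), whereas on the core of compound 1 the same kind of change made a 2.3-fold higher number from compound 1 to compound 3 (0.37 log units; beyond the scatter). The change therefore does not carry from one core to the other with a fixed direction or size: the same change on two cores in this assay, a 2.3-fold higher number (0.37 log units; beyond the scatter) from compound 1 to compound 3 and an at least 6.6-fold lower number (0.82 log units; beyond the scatter) from compound 2 to compound 4, at least 15-fold (1.19 log units) apart, beyond the scatter of two such steps Compound 2 stands at a limit and not at a number, so only a lower bound is known for the size of its step, and the data do not show why the two cores respond differently: the limit of > 100000 nM in this assay, at which 1 of the 4 values shown sits.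

With one pair on each core, the compounds shown give no general rule for other cores, and they leave open how the step depends on the group on the ring nitrogen, as only a methyl group and the large group of compound 1 appear there. Also open, going by these compounds, is whether a longer chain in place of that methyl group would move the step towards the one seen on the core of compound 1, and whether an amine or a carboxylic acid in place of cyano would behave the same way on both cores.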